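A few compounds are considered here, and "the series" means these few. Any claim that something is new, unique, unknown or untested is made for them only; others in the source may bear on it.

Within the data shown here, in an ADME assay on microsomes (Homo sapiens) for metabolic stability (on this read-out lower numbers stand for slow clearance and higher numbers for fast clearance), compound 2 `CNC(=O)[C@@H]1CCCN1S(=O)(=O)c1ccc(Cl)c(COc2cccc3c(C(F)(F)F)cc(C)nc23)c1Cl` gives 250 mL/min/kg, the higher of the two numbers measured so far. By comparison, compound 1 `CNC(=O)[C@@H]1CCCN1S(=O)(=O)c1ccc(Cl)c(COc2cccc3c(-n4ccnc4)cc(C)nc23)c1Cl` gives 33.3 mL/min/kg. Among the measured compounds shown here, the only measured step is a 7.5-fold higher number from compound 1 to compound 2 (0.88 log units; beyond the scatter), seen when trifluoromethyl replaces 1H-imidazol-1-yl on an aromatic carbon. Compound 3 `Cc1cc(C(F)(F)F)c2cccc(OCc3c(Cl)ccc(S(=O)(=O)N4CCC[C@H]4C(=O)O)c3Cl)c2n1` keeps the trifluoromethyl of compound 2 and differs elsewhere: hydroxy in place of methylamino on a carbonyl carbon. Put simply, hydroxy takes the place of methylamino on a carbonyl carbon, which turns methylcarbamoyl into carboxy. For the measured compounds named here, no measured step touches that carbonyl carbon, so the one available step bears on this change only loosely. It shows that one change in this small set can shift the clearance beyond the scatter, but it gives no direction for the new change. Going by the values given here, compound 2 holds the higher of only two numbers, so a fall seems somewhat more likely than a rise, though this remains a weakly supported expectation. The estimated change is a 3.1-fold lower number from compound 2 to compound 3 (0.49 log units; beyond the scatter). For compound 3 the expected clearance is 80 mL/min/kg, with an estimated range from 20 mL/min/kg to 250 mL/min/kg.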

Compound 3, clearance: 8.33 mL/min/kg
Estimate against measurement, compound 3: 9.6-fold (0.98 log units) above; the measured number lies below the stated range.
By their numbers in this assay, from the lowest: compound 3; then compound 1; then compound 2.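

In this assay, replacing methylamino with hydroxy on the carbonyl carbon, which turns methylcarbamoyl into carboxy, gives a 30-fold lower number from compound 2 to compound 3 (1.48 log units; beyond the scatter). Among these compounds, until now, the only measured change was on an aromatic carbon of the shared core, so this is the first sign that the clearance also responds to a change at the far end of the molecule, on the 2-(methylcarbamoyl)pyrrolidin-1-yl group. It is also the larger of the two measured steps, the other being a 7.5-fold higher number from compound 1 to compound 2 (0.88 log units; beyond the scatter), although nothing measured here explains why this single replacement has such a large effect.

The compounds shown leave open whether the same change from methylcarbamoyl to carboxy would lower the number to a similar extent with 1H-imidazol-1-yl in place of trifluoromethyl, since this step has been read only with trifluoromethyl on the core. They also leave open how other groups on this carbonyl carbon would compare, such as a plain amino group, dimethylamino or a methoxy group, and so whether the fall is specific to hydroxy or would appear with any replacement of methylamino.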